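From fluoro to chloro: what to expect for compound 4

The compounds below may be only part of what the source reports. "The series", "measured", "known", "first", "only" and "open" are said of these compounds alone.

Three members of the series have been run in an ADME assay on the whole organism with Oryza sativa as the target, tested at 10 uM; on this read-out higher numbers stand for a weaker effect at the one concentration tested and lower numbers for a stronger effect. Compound 1 `Cc1cccc(NC(=O)N[C@H](C)c2ccccc2)c1` gives 47%, compound 2 `CC(C)c1cccc(NC(=O)N[C@H](C)c2ccccc2)c1` gives 44% and compound 3 `C[C@@H](NC(=O)Nc1cccc(F)c1)c1ccccc1` gives 84%. On these numbers compound 3 stands highest of the three: the step of a number 37 percentage points higher from compound 1 to compound 3 (beyond the scatter) marks its nearest neighbour, the step of a number 40 percentage points higher from compound 2 to compound 3 (beyond the scatter) its furthest. The remaining step, a number 3 percentage points lower from compound 1 to compound 2 (within the scatter), is within the scatter.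

Compound 4 `C[C@@H](NC(=O)Nc1cccc(Cl)c1)c1ccccc1` is the next member due in this assay. Against compound 3 it changes in one place: chloro in place of fluoro on an aromatic carbon. For the measured compounds named here, no measured step bears directly on a halogen-for-halogen exchange. Going by the values given here, the two large steps both end at compound 3 and both replace an alkyl group by fluoro; the only step between two groups of one kind, methyl to isopropyl, stays within the scatter. The working reading is therefore that compound 3 is the anchor and that trading fluoro for chloro moves the number little. The expected step for compound 4 is a number 8 percentage points lower from compound 3 to compound 4 (within the scatter), which is not beyond the scatter. Compound 4 is estimated at 76%, with a range from 55% to 92%.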

Compound 4, a percentage reported as activity, at one concentration (the size of the read-out at that concentration, not a potency): 83%
Estimate against measurement, compound 4: 7 percentage points below; the range from low to high includes it.
By their numbers in this assay, from the lowest: compounds 2 and 1 (each within the scatter of the next); then compounds 4 and 3 (each within the scatter of the next).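

In this assay, for the compounds shown here, the exchange of one halogen for another on this aromatic carbon, meta to a large group, gives a number 1 percentage points lower from compound 3 to compound 4 (within the scatter) and so provides the first direct reading of this kind of change. The gap to the alkyl compounds also proves not to be confined to fluoro, since a number 39 percentage points higher from compound 2 to compound 4 (beyond the scatter) and a number 36 percentage points higher from compound 1 to compound 4 (beyond the scatter) are both large and leave the two halogen compounds apart from the two alkyl compounds, with none of the four going against that split. Nothing available explains this split between halogen and alkyl groups at this position.

Going by these compounds alone, with only two groups of each kind, it remains open whether the split really follows halogen against alkyl or is a feature of these four groups alone. Bromo would extend the halogen side, while a methoxy group, an amine or a carboxylic acid at the same place would show where groups of other kinds fall relative to the two clusters.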